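Swapping the bromo group on compound 3

This account rests on a few compounds, and the source may have more. Where it says the series, first, only, none or still open, it means among the compounds named here.

In a functional assay on B16 cells (Mus musculus) for inhibition (on this read-out lower numbers stand for stronger inhibition and higher numbers for weaker inhibition), compound 1 `CC(C)CN(NC(=O)OCc1ccccc1)C(=O)CN(Cc1ccccc1)NC(=O)CBr` gives 1400 nM while compound 2 `O=C(CN(Cc1ccccc1)NC(=O)CBr)NNC(=O)OCc1ccccc1` gives 700 nM and compound 3 `CC(C)CN(CC(=O)NN(Cc1ccccc1)c1cnccn1)NC(=O)CBr` gives 11400 nM on the same read-out. Compound 3 has the highest number of the three, and its gap to each of the other two lies beyond the scatter, so it is the weakest inhibitor of this small set.

Compound 4 `CC(C)CN(CC(=O)NN(Cc1ccccc1)c1cnccn1)NC(=O)Cc1cccc(Br)c1` is compound 3 with 3-bromophenyl in place of bromo on a saturated chain carbon bound to a carbonyl carbon. Cut one bond further out, this reads bromomethyl to 3-bromobenzyl.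

For the measured compounds named here, the only measured step is a 2.0-fold lower number from compound 1 to compound 2 (0.30 log units; within the scatter) and it stays within the scatter. That step puts hydrogen in place of isobutyl on an amide-type nitrogen, elsewhere in the molecule, so it bears only weakly on this change. All three measured compounds keep the bromomethyl end, and no measurement shows what happens when it is replaced. The expectation is therefore loose, leaning towards a somewhat higher number than the 11400 nM of compound 3 in this assay but with a range that also allows no real change. The estimate is a 1.8-fold higher number from compound 3 to compound 4 (0.24 log units; within the scatter) in this reading. For compound 4 the expected value is 20000 nM with an estimated range from 5000 nM to 80000 nM in this test.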

Compound 4, half-maximal inhibitory concentration: 23400 nM
The estimate for compound 4 lay 1.2-fold (0.07 log units) below the measured number; measured number inside the range.
By their numbers in this assay, from the lowest: compounds 2 and 1 (each within the scatter of the next); then compound 3; then compound 4.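

For the compounds shown here, this is the first measurement at this position. In this assay, the change from bromomethyl to 3-bromobenzyl gives a 2.1-fold higher number from compound 3 to compound 4 (0.31 log units; beyond the scatter), so what sits at this end of the molecule does affect the read-out, and here the direction is towards weaker inhibition. The step is small for such a large swap: a single bromine leaves, an aromatic ring of carbon with its own bromine enters, seven heavy atoms in all, and compound 4 still gives a measurable 23400 nM, which shows that the bromomethyl end is not required for a number on this read-out. Nothing at hand bears on the reason for this rise.

Going by these compounds, how a plain benzyl group, an aminomethyl group or a longer chain ending in a carboxylic acid would read at this position stays open, and with it whether the bromine on the new ring matters at all. Going by these compounds alone, also open is whether the same swap would shift the number by a similar amount on compound 2, which carries the lowest number of the earlier compounds.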